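The compounds below may be only part of what the source reports. "The series", "measured", "known", "first", "only" and "open" are said of these compounds alone.

In a functional assay on SMMC-7721 cells (Homo sapiens) for cytotoxicity, read by MTT assay, with a stated time of 24 h (a lower number here means a stronger inhibitor, a higher number a weaker inhibitor), compound 1 (`COc1cc(/C=C2\CN(S(=O)(=O)c3ccc(F)cc3)C/C(=C\c3ccccc3F)C2=O)cc(OC)c1OC`) gives 6340 nM and compound 2 (`CC(=O)Nc1ccc(S(=O)(=O)N2C/C(=C\c3cccc([N+](=O)[O-])c3)C(=O)/C(=C/c3ccccc3F)C2)cc1`) gives 10200 nM as its value, so the two stand within the scatter of each other. Compound 3 (`COc1cc(/C=C2\CN(S(=O)(=O)c3ccc(NC(C)=O)cc3)C/C(=C\c3ccccc3F)C2=O)cc(OC)c1OC`) differs from compound 2 in one place (3,4,5-trimethoxyphenyl in place of 3-nitrophenyl on a double-bonded chain carbon bound to a double-bonded ring carbon): 3,4,5-trimethoxyphenyl in place of 3-nitrophenyl on a double-bonded chain carbon bound to a double-bonded ring carbon. Compound 1 also carries 3,4,5-trimethoxyphenyl there and gives 6340 nM as noted. No step beyond the scatter is expected in this assay for this change, and the estimated step is a 1.4-fold lower number from compound 2 to compound 3 (0.13 log units; within the scatter) in size. For compound 3 the expected value is 7500 nM with a range between 3500 nM and 15000 nM as its bounds.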

Compound 3, half-maximal inhibitory concentration: 3920 nM
For compound 3 the middle estimate is 1.9-fold (0.28 log units) above the measured one; low and high end bracket the measured number.
By their numbers in this assay, from the lowest: compounds 3, 1 and 2 (each within the scatter of the next, the first and the last beyond it).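

In this assay, 3,4,5-trimethoxyphenyl in place of 3-nitrophenyl on a double-bonded chain carbon bound to a double-bonded ring carbon gives a 2.6-fold lower number from compound 2 to compound 3 (0.42 log units; beyond the scatter), the first step among these compounds that lies beyond the scatter. Acetamido in place of fluoro on an aromatic carbon gives a 1.6-fold lower number from compound 1 to compound 3 (0.21 log units; within the scatter), which stays within the scatter. No evidence at hand bears on this result. The compounds shown leave open whether the step follows from gaining the methoxy groups or from losing the nitro group. An unsubstituted phenyl or an aminophenyl at this place could separate the two.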